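Cytotoxicity notes on a nitrophenylthio anilide series

This account rests on a few compounds, and the source may have more. Where it says the series, first, only, none or still open, it means among the compounds named here.

Measured so far:
- compound 1, `COc1ccccc1C(=O)Nc1nc(Cl)ncc1Sc1ccc([N+](=O)[O-])cc1`, 480000 nM
- compound 2, `COc1ccccc1NC(=O)c1ccccc1Sc1ccc([N+](=O)[O-])cc1`, "not determined" (no result reported)
- compound 3, `COc1ccccc1NC(=O)c1sccc1Sc1ccc([N+](=O)[O-])cc1`, 472000 nM

In an ADME assay on H9 cells (Homo sapiens) for cytotoxicity, read by MTT assay, with a stated time of 7 days (on this read-out lower numbers stand for higher toxicity in this test and higher numbers for lower toxicity in this test), compound 1 gives 480000 nM, and compound 3 gives 472000 nM; the two numbers lie within the scatter of each other, so no order between them can be read. Compound 2 gives "not determined" (no result reported) in this assay and therefore stands nowhere on the numbers shown; it serves only as the structural starting point for the next compound.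

Compound 4, `COc1ccccc1NC(=O)c1cc(Cl)ccc1Sc1ccc([N+](=O)[O-])cc1`, differs from compound 2 by one change: chloro in place of hydrogen on an aromatic carbon. Going by the values given here, no step between measured compounds describes this kind of change, so its size in this assay is unknown from the data. The two numbers that exist, from compound 1 and compound 3, sit close together despite quite different cores, and on that basis the step from compound 2 to compound 4 is expected to be small, with no direction beyond the scatter.

Compound 4 is expected to give about 400000 nM in this assay, within a range of 150000 nM to 1000000 nM.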

Compound 4, half-maximal cytotoxic concentration: 483000 nM
The estimate for compound 4 lay 1.2-fold (0.08 log units) below the measured number; measured number inside the range.
By their numbers in this assay, from the lowest: compounds 3, 1 and 4 (each within the scatter of the next).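

No step can be read from compound 2 to compound 4: compound 2 has no number in this assay. The compounds shown leave open what chloro in place of hydrogen does in this assay. No data shown bear on an explanation of the result.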